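The source may hold more compounds than are shown below. What is called first, only, known or untested is meant among the compounds shown, and "the series" means these compounds.

Measured compounds:
compound 1, `CC1CCN(c2c(S(=O)(=O)c3cccc(F)c3)cnc3ccc(F)cc23)CC1`: 76%
compound 2, `Cc1ccc(S(=O)(=O)c2cnc3ccc(F)cc3c2N2CCC(C)CC2)cc1F`: 86%

In an assay on isolated protein for displacement of a labelled ligand from metabotropic glutamate receptor 5 (Homo sapiens), with a stated time of 60 min, tested at 1 uM (on this read-out higher numbers stand for more inhibition at the one concentration tested (going by the name of the read-out) and lower numbers for less inhibition), compound 2 gives 86%, the larger of the two numbers at hand. Its nearest neighbour is compound 1, which in this assay gives 76%; the step of a number 10 percentage points higher from compound 1 to compound 2 (within the scatter), methyl in place of hydrogen on an aromatic carbon, stays within the scatter, so the two compounds cannot be set apart on these numbers.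

Compound 3, `Cc1ccc2ncc(S(=O)(=O)c3ccc(C)c(F)c3)c(N3CCC(C)CC3)c2c1`, differs from compound 2 in one place: methyl in place of fluoro on an aromatic carbon. For the measured compounds named here, no measured step touches this exact change; the only step known, from compound 1 to compound 2, also brings in a methyl, but on a different ring and against hydrogen rather than fluoro, and it was within the scatter. Going by the values given here, with a single small step as the sole guide, no movement beyond the scatter is expected for compound 3 in this assay, and the step of a number 2 percentage points lower from compound 2 to compound 3 (within the scatter) is estimated to be small. Compound 3 is therefore expected to give about 84%, within a range from 70% to 95%.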

Compound 3, a percentage reported as inhibition, at one concentration (the size of the read-out at that concentration, not a potency): 91%
Compound 3: middle estimate off by 7 percentage points, on the low side, and the stated range covers the measured number.
By their numbers in this assay, from the lowest: compounds 1, 2 and 3 (each within the scatter of the next, the first and the last beyond it).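

With compound 3 the change moves to a place the earlier step did not touch: on an aromatic carbon of a six-membered aromatic ring of carbon only, part of a fused or bridged system of two rings, methyl takes the place of fluoro. The outcome in this assay is a number 5 percentage points higher from compound 2 to compound 3 (within the scatter) and so compound 2 and compound 3 cannot be set apart on these numbers, which shows that at this position the read-out stays within the scatter whether the group is fluoro or methyl. Nothing available accounts for this result, and no explanation can be offered for it.

What the compounds shown leave open is how this position would respond to a group that differs more from fluoro and methyl, such as an amine, a carboxylic acid or a longer chain. Because the read-out is a single percentage at one concentration, they also leave open whether compound 2 and compound 3 would still be indistinguishable in a full measurement of potency.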